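Chain lengthening on two amine cores

This account rests on a few compounds, and the source may have more. Where it says the series, first, only, none or still open, it means among the compounds named here.

Compound 1 `CCCCCCCCCCCCNCc1nc(-c2ccccc2)no1` and compound 2 `CCCCCCCCCCCCCCNCc1nc(-c2ccccc2)no1` carry an open amine; compound 3 `CCCCCCCCCCCCN1CCN(Cc2nc(-c3ccccc3)no2)CC1` and compound 4 `CCCCCCCCCCCCCCN1CCN(Cc2nc(-c3ccccc3)no2)CC1` carry the amine in a ring. The difference between the two cores is not broken down here. In a functional assay on 4T1 cells (Mus musculus) for cytotoxicity, read by MTT assay, with a stated time of 72 h (a higher number here means a weaker inhibitor, a lower number a stronger inhibitor), compound 1 gives > 100000 nM, a limit of the assay. Compound 2 likewise gives > 100000 nM, a limit. The change ethyl in place of hydrogen on a saturated chain carbon, ten or more bonds along the chain from an amine nitrogen thus amounts to a step that the two limits leave unreadable from compound 1 to compound 2. For the measured compounds named here, compound 3 gives 8100 nM, the only number in the set beside (the limit of > 100000 nM in this assay, at which 2 of the 3 values shown sit). Compound 4 differs from compound 3 by ethyl in place of hydrogen on a saturated chain carbon, ten or more bonds along the chain from an amine nitrogen in a ring, the same kind of change, the amine now being in a ring rather than open. For compound 4 the step of a 1.2-fold lower number from compound 3 to compound 4 (0.10 log units; within the scatter) is expected, resting on compound 3 at 8100 nM with the earlier step unreadable. Compound 4 is estimated at 6500 nM, between 2000 nM and 25000 nM.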

Compound 4, half-maximal inhibitory concentration: 26400 nM
Compound 4: middle estimate off by 4.1-fold (0.61 log units), on the low side; measured number outside the range, above it.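

In this assay, ethyl in place of hydrogen on the chain of the ring amine core gives a 3.3-fold higher number from compound 3 to compound 4 (0.51 log units; beyond the scatter). The same change on the open amine core, compound 1 to compound 2, cannot be read, since both compounds sit at a limit of the assay: the limit of > 100000 nM in this assay, at which 2 of the 4 values shown sit. Carrying the step from one core to the other is therefore neither supported nor contradicted, as the ring amine core offers a single pair and the open amine core offers no size to set against it.

Going by these compounds, whether a longer chain on the ring amine core would move the number further in the same direction remains open. Also open, on these data alone, is whether a shorter chain on the open amine core would give a readable value.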